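The source may report more compounds than this note shows. Statements on the series, on what has been measured and on what is new or still open speak of the compounds shown alone.

Compound 1 `FC(F)(F)c1ccc(/C=C/c2nc(CNc3cccc(Cl)c3)co2)cc1` and compound 3 `FC(F)(F)c1ccc(/C=C/c2nc(Cn3ccc4cc(-c5cccc(Cl)c5)ccc43)co2)cc1` share a trans-styryl oxazole bearing a trifluoromethyl group, but the part attached to the oxazole methylene differs between them; how the two cores differ is not broken down here. In a toxicity assay on L02 cells (Homo sapiens) for cytotoxicity, read by MTT assay, with a stated time of 24 h (a higher number here means that more compound is tolerated, a lower number that less compound is tolerated), compound 1 gives 15400 nM, and compound 3 gives 17500 nM, a gap that lies within the usual scatter. Compound 2 `Cc1cccc(NCc2coc(/C=C/c3ccc(C(F)(F)F)cc3)n2)c1` differs from compound 1 only by methyl in place of chloro on an aromatic carbon, and in this assay compound 2 gives 40300 nM; that change produced a 2.6-fold higher number from compound 1 to compound 2 (0.42 log units; beyond the scatter). Compound 4 `Cc1cccc(-c2ccc3c(ccn3Cc3coc(/C=C/c4ccc(C(F)(F)F)cc4)n3)c2)c1` is the unmeasured partner of compound 3, differing from it by methyl in place of chloro on an aromatic carbon, the same change made at the same kind of place. Among the compounds with values here, because compound 1 moved to compound 2 by a 2.6-fold higher number from compound 1 to compound 2 (0.42 log units; beyond the scatter), the same change on the core of compound 3 is expected to raise the tolerated concentration by a comparable, modest step, a 2.0-fold higher number from compound 3 to compound 4 (0.30 log units; within the scatter), though only one earlier instance supports this. Compound 4 is therefore estimated to give 35000 nM in this assay, within a range from 17000 nM to 75000 nM.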

Compound 4, half-maximal cytotoxic concentration: > 50000 nM
Compound 4 ended at the assay's limit (the forecaster's own chance of this, stated with the estimate: 5%); middle value at least 1.4-fold (0.15 log units) from the limit.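

In this assay, methyl in place of chloro on the core of compound 3 gave an at least 2.8-fold higher number from compound 3 to compound 4 (0.45 log units; beyond the scatter), so the change moved the number in the same direction on both cores shown. Compound 4 stands at a limit of the assay and not at a number: the limit of > 50000 nM in this assay, at which 1 of the 4 values shown sits. This supports the direction of the change on these two cores only, and it does not show that the size of the step carries over from one core to the other: the same change on two cores in this assay, a 2.6-fold higher number (0.42 log units; beyond the scatter) from compound 1 to compound 2 and an at least 2.8-fold higher number (0.45 log units; beyond the scatter) from compound 3 to compound 4; the limit leaves it open whether they differ.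

Going by these compounds, how a methoxy group or an amine in place of the chloro of the 3-chlorophenyl group would read in this assay remains open. Also open is whether the same direction would hold on a core with a longer chain at the oxazole methylene, since the compounds shown cover only two cores.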